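Adding a Second Chloro to the Five-Membered Ring

The compounds below may be only part of what the source reports. "The series", "measured", "known", "first", "only" and "open" are said of these compounds alone.

Compound 1 `O=[N+]([O-])c1ccc(S(=O)(=O)Nc2cccc3cc[nH]c23)cc1` and compound 2 `O=[N+]([O-])c1ccc(S(=O)(=O)Nc2cccc3cc(Cl)[nH]c23)cc1` share one core. In a functional assay on KB cells (Homo sapiens) for antiproliferative activity, read by colorimetric assay and MTT assay (a lower number here means a stronger inhibitor, a higher number a weaker inhibitor), compound 1 gives 15 ug/mL, and compound 2 gives 18 ug/mL. The change is chloro in place of hydrogen on an aromatic carbon, and it made a 1.2-fold higher number from compound 1 to compound 2 (0.08 log units; within the scatter). Compound 3 `N#Cc1ccc(S(=O)(=O)Nc2ccc(Cl)c3cc[nH]c23)cc1` rests on a different core; the difference between the two cores is not broken down here. In this assay compound 3 gives 15 ug/mL. Compound 4 `N#Cc1ccc(S(=O)(=O)Nc2ccc(Cl)c3c(Cl)c[nH]c23)cc1` differs from compound 3 by chloro in place of hydrogen on an aromatic carbon. This is the same kind of change as that from compound 1 to compound 2, though the place is not identical: in compound 2 the chloro sits next to the ring nitrogen, in compound 4 two ring bonds from the ring nitrogen. Because a 1.2-fold higher number from compound 1 to compound 2 (0.08 log units; within the scatter) stayed within the scatter, only a small step is expected for compound 4, namely a 1.1-fold higher number from compound 3 to compound 4 (0.05 log units; within the scatter). For compound 4 in this assay the estimate is 17 ug/mL, expected to lie between 9 ug/mL and 32 ug/mL.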

Compound 4, half-maximal inhibitory concentration: 13 ug/mL
Estimate against measurement, compound 4: 1.3-fold (0.12 log units) above; measured number inside the range.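

In this assay chloro in place of hydrogen on an aromatic carbon gave a 1.2-fold lower number from compound 3 to compound 4 (0.06 log units; within the scatter), and the two steps do not differ beyond the scatter: the same change on two cores in this assay, a 1.2-fold higher number (0.08 log units; within the scatter) from compound 1 to compound 2 and a 1.2-fold lower number (0.06 log units; within the scatter) from compound 3 to compound 4, 1.4-fold (0.14 log units) apart, within the scatter of two such steps. On these two cores, then, neither step moved the number beyond the scatter, and the change looks equally silent on both. This does not show that the effect of the change carries over from one core to the other: the chloro sits at a different place in each pair, and steps this small reveal no direction.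

The compounds shown leave open whether a different group at these places, such as an amine or a carboxylic acid, would shift the number beyond the scatter.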